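Acetyl to Phenylsulfonyl at a Saturated Oxygen

The compounds below may be only part of what the source reports. "The series", "measured", "known", "first", "only" and "open" are said of these compounds alone.

Compound 2 `CC(=O)OC1CCC(CN2CCN(c3cc(=O)c4cc(C(F)(F)F)cc([N+](=O)[O-])c4s3)CC2)CC1` was examined in an ADME assay on Vero cells (Chlorocebus sabaeus) for cytotoxicity, read by MTT assay, with a stated time of 48 h; a higher number here means a weaker inhibitor, a lower number a stronger inhibitor. In this assay compound 2 gives > 64 ug/mL, which is a limit of the assay rather than a number. Its neighbour compound 1 `CS(=O)(=O)OC1CCC(CN2CCN(c3cc(=O)c4cc(C(F)(F)F)cc([N+](=O)[O-])c4s3)CC2)CC1` carries a methylsulfonyl where compound 2 carries an acetyl. In this assay compound 1 gives > 64 ug/mL, again a limit and not a number. The step that the two limits leave unreadable from compound 1 to compound 2 therefore cannot be read, because both compounds sit at the limit of > 64 ug/mL in this assay, at which 2 of the 2 values shown sit.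

Compound 3 `O=c1cc(N2CCN(CC3CCC(OS(=O)(=O)c4ccccc4)CC3)CC2)sc2c([N+](=O)[O-])cc(C(F)(F)F)cc12` has not yet been measured. It differs from compound 2 in one place: phenylsulfonyl in place of acetyl on an oxygen on a saturated carbon. For the measured compounds named here, the only measured step in this set is the unreadable one from compound 1 to compound 2, so no size of effect for a change at this oxygen can be drawn from the data.

The expectation for compound 3 is that it too will sit at the limit, with a step that the limit leaves unreadable from compound 2 to compound 3 expected to be no larger than the scatter. For compound 3 the estimated value in this assay is 80 ug/mL, expected to lie between 40 ug/mL and 200 ug/mL.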

Compound 3, half-maximal inhibitory concentration: > 64 ug/mL
Compound 3 gave a limit, no number (the forecaster's own chance of this, stated with the estimate: 75%); the middle value does not contradict the limit.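

No step can be read among compound 1, compound 2 and compound 3 in this assay, because all three sit at the same limit: the limit of > 64 ug/mL in this assay, at which 3 of the 3 values shown sit.

The compounds shown leave open whether acetyl, methylsulfonyl or phenylsulfonyl on this oxygen makes any difference in this assay, as none of the three gives a number.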